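The compounds below may be only part of what the source reports. "The series", "measured", "known", "first", "only" and "open" are said of these compounds alone.

Compound 1 `FC(F)(F)c1ccc(CSc2nc(Nc3ccccc3C(F)(F)F)c3ccccc3n2)cc1` is measured in a functional assay on MCF7 cells (Homo sapiens) for cytotoxicity, read by MTT assay, with a stated time of 72 h (on this read-out higher numbers stand for weaker inhibition and lower numbers for stronger inhibition), only as a limit, > 50000 nM, so its standing is known solely as a bound. Compound 2 `Fc1ccc(Nc2nc(SCc3ccc(C(F)(F)F)cc3)nc3ccccc23)cc1` gives 36300 nM in this assay, and compound 3 `FC(F)(F)c1ccc(CSc2nc(Nc3ccc(Cl)cc3)c3ccccc3n2)cc1` gives 21500 nM. Compound 4 `COc1ccc(Nc2nc(SCc3ccc(C(F)(F)F)cc3)nc3ccccc23)cc1` differs from compound 1 by 4-methoxyphenyl in place of 2-(trifluoromethyl)phenyl on a nitrogen on an aromatic ring. The two measured steps that replace the same 2-(trifluoromethyl)phenyl bear on this change: an at least 1.3-fold lower number from compound 1 to compound 2 (0.13 log units; that floor lies within the scatter) and an at least 2.3-fold lower number from compound 1 to compound 3 (0.36 log units; beyond the scatter), both moving to a lower number, while a 1.7-fold lower number from compound 2 to compound 3 (0.23 log units; within the scatter) shows the two 4-substituted phenyls close to each other. A downward step of comparable size is therefore expected for compound 4, an at least 2.0-fold lower number from compound 1 to compound 4 (0.30 log units; that floor lies within the scatter). Compound 4 is estimated to give 25000 nM in this assay, within a range from 10000 nM to 60000 nM.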

Compound 4, half-maximal inhibitory concentration: 47200 nM
Compound 4: the middle estimate sits 1.9-fold (0.28 log units) below what was measured; low and high end bracket the measured number.
By their numbers in this assay, from the lowest: compounds 3, 2 and 4 (each within the scatter of the next, the first and the last beyond it). At a limit, above all of these: compound 1.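

In this assay, for the compounds shown here, methoxy in place of chloro gives a 2.2-fold higher number from compound 3 to compound 4 (0.34 log units; beyond the scatter), the first change among the 4-substituted phenyls to pass the scatter, while methoxy in place of fluoro gives only a 1.3-fold higher number from compound 2 to compound 4 (0.11 log units; within the scatter). Replacing 2-(trifluoromethyl)phenyl with 4-methoxyphenyl gives an at least 1.0-fold lower number from compound 1 to compound 4 (0.02 log units; that floor lies within the scatter), so this change shows no firm gain. That step is only a floor, since compound 1 stands at a limit: the limit of > 50000 nM in this assay, at which 1 of the 4 values shown sits.

Going by these compounds, how far compound 1 truly lies from compound 4 stays open. So does whether an amine or a carboxylic acid on this phenyl would shift the number further.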